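Adding a Second Chloro to a Dichloro Core Analogue

This account rests on a few compounds, and the source may have more. Where it says the series, first, only, none or still open, it means among the compounds named here.

Compound 1 `ClCc1ccc(Cn2cnc3c(Cl)ncnc32)cc1` is one of two compounds tested in a functional assay on HOP-62 cells (Homo sapiens) for cytotoxicity, read by sulforhodamine B assay, with a stated time of 48 h; on this read-out higher numbers stand for weaker inhibition of growth and lower numbers for stronger inhibition of growth; in this assay compound 1 gives 1940 nM. The other, compound 2 `ClCc1cccc(Cn2cnc3c(Cl)nc(Cl)nc32)c1`, carries a second chloro on the shared core and gives 2290 nM, a number that lies within the usual scatter of that for compound 1. Compound 3 `ClCc1ccc(Cn2cnc3c(Cl)nc(Cl)nc32)cc1` is not yet measured. It differs from compound 1 by chloro in place of hydrogen on an aromatic carbon. With only these two numbers to draw on, the step from compound 1 to compound 3 in this assay is expected to stay within the scatter, giving a 1.1-fold higher number from compound 1 to compound 3 (0.03 log units; within the scatter). Compound 3 is therefore estimated at 2100 nM, with a range from 900 nM to 5000 nM.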

Compound 3, concentration for 50% growth inhibition: 2190 nM
Compound 3: the middle estimate sits 1.0-fold (0.02 log units) below what was measured; measured number inside the range.
By their numbers in this assay, from the lowest: compounds 1, 3 and 2 (each within the scatter of the next).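

In this assay, chloro in place of hydrogen on the aromatic carbon between two ring nitrogen atoms gives a 1.1-fold higher number from compound 1 to compound 3 (0.05 log units; within the scatter). Within the data shown here, this is the first comparison of compounds that differ in one place, and it shows that a chloro can sit at this position with no change in growth inhibition beyond the scatter. Nothing at hand gives a reason for this result. On these data alone, whether an amine or a methoxy group at the same position would also leave the number within the scatter remains open.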